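The source may hold more compounds than are shown below. What is called first, only, known or untested is meant among the compounds shown, and "the series" means these compounds.

Of the compounds shown here, two that share one core have so far been tested in a functional assay on the whole organism with Rattus norvegicus as the target; a higher number here means that more compound is needed for the effect, a lower number that less compound is needed. In this assay compound 1 `CC1CCC(/C=N/c2ccc(O)cc2)=C2NC=C(C(=O)O)C(=O)N21` gives 1.2 umol/kg. Among the measured compounds shown here, compound 2 `Cc1ccc(/N=C/C2=C3NC=C(C(=O)O)C(=O)N3C(C)CC2)cc1` gives 3.6 umol/kg, the higher of the two numbers; the only neighbour is compound 1, lower by the step of a 3.0-fold higher number from compound 1 to compound 2 (0.48 log units; beyond the scatter), which came from a methyl in place of a hydroxy on an aromatic carbon.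

Compound 3 `CC(=O)c1ccc(/N=C/C2=C3NC=C(C(=O)O)C(=O)N3C(C)CC2)cc1` has not yet been measured. It differs from compound 2 in one place: acetyl in place of methyl on an aromatic carbon. For the measured compounds named here, the only measured step, a 3.0-fold higher number from compound 1 to compound 2 (0.48 log units; beyond the scatter), concerns the same aromatic carbon and was modest, but it does not involve an acetyl, so it gives little guidance on direction. The change from methyl to acetyl is therefore expected to move the number only modestly, with the step of a 1.0-fold lower number from compound 2 to compound 3 (0.01 log units; within the scatter) likely within the scatter. For compound 3 the estimate is 3.5 umol/kg, with a range from 1.2 umol/kg to 11 umol/kg.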

Compound 3, dose for 50% inhibition: 0.75 umol/kg
Estimate against measurement, compound 3: 4.7-fold (0.67 log units) above; measured number below the stated range.
By their numbers in this assay, from the lowest: compounds 3 and 1 (each within the scatter of the next); then compound 2.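

At this aromatic carbon, para to a large group, the choice of group matters in both directions: in this assay, putting acetyl in place of methyl gives a 4.8-fold lower number from compound 2 to compound 3 (0.68 log units; beyond the scatter), so methyl is the group that stands apart from the other two. Hydroxy and acetyl cannot be separated, since acetyl in place of hydroxy gives a 1.6-fold lower number from compound 1 to compound 3 (0.20 log units; within the scatter), even though the two groups differ in size. Nothing available explains why methyl requires more compound than either of them.

Three groups at one position are too few to show what the hydroxy and acetyl compounds have in common. As far as these compounds go, it remains open whether an amine, a nitrile or a longer chain such as propanoyl would match these two compounds or fall closer to compound 2.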